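A few compounds are considered here, and "the series" means these few. Any claim that something is new, unique, unknown or untested is made for them only; others in the source may bear on it.

Measured compounds in a functional assay on MGC-803 cells (Homo sapiens) for cytotoxicity, read by MTT assay, with a stated time of 72 h; on this read-out higher numbers stand for weaker inhibition and lower numbers for stronger inhibition:

Compound 1, `CCCCCCNc1nc(SCc2ccc(C(F)(F)F)cc2)nc2ccccc12`: 13100 nM
Compound 2, `FC(F)(F)c1ccc(CSc2nc(Nc3ccccc3)c3ccccc3n2)cc1`: 22200 nM
Compound 3, `FC(F)(F)c1ccc(CSc2nc(Nc3cccc(Br)c3)c3ccccc3n2)cc1`: 23700 nM

Compound 3 shows the highest of the three numbers, yet the step of a 1.1-fold higher number from compound 2 to compound 3 (0.03 log units; within the scatter) and the step of a 1.8-fold higher number from compound 1 to compound 3 (0.26 log units; within the scatter) both stay within the scatter, so no real ordering among the three can be claimed; all three sit close together at weak inhibition.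

Compound 4, `O=[N+]([O-])c1ccc(Nc2nc(SCc3ccc(C(F)(F)F)cc3)nc3ccccc23)cc1`, differs from compound 3 in one place: 4-nitrophenyl in place of 3-bromophenyl on a nitrogen on an aromatic ring. Two of the measured steps speak to this kind of change. Swapping the whole hexyl chain for a phenyl gave a 1.7-fold higher number from compound 1 to compound 2 (0.23 log units; within the scatter), and adding a bromine on that phenyl gave a 1.1-fold higher number from compound 2 to compound 3 (0.03 log units; within the scatter); neither moved the number beyond the scatter. For the measured compounds named here, none of the measured compounds carries a nitro group, so the data give no direct guide to what a 4-nitrophenyl does here, only the observation that changes on this nitrogen have so far left the read-out roughly where it was.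

On that basis, the expected step of a 1.1-fold higher number from compound 3 to compound 4 (0.02 log units; within the scatter) is none beyond the scatter. For compound 4 the estimated value in this assay is 25000 nM, with a range from 10000 nM to 60000 nM.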

Compound 4, half-maximal inhibitory concentration: 8170 nM
The estimate for compound 4 lay 3.1-fold (0.49 log units) above the measured number; the measured number lies below the stated range.
By their numbers in this assay, from the lowest: compounds 4, 1, 2 and 3 (each within the scatter of the next, the first and the last beyond it).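

On the phenyl attached to this nitrogen, a group can shift the number beyond the scatter in this assay: nitro in place of hydrogen gave a modest step (a 2.7-fold lower number from compound 2 to compound 4 (0.43 log units; beyond the scatter)), and 4-nitrophenyl in place of 3-bromophenyl gave a similar one (a 2.9-fold lower number from compound 3 to compound 4 (0.46 log units; beyond the scatter)), whereas bromo in place of hydrogen did not (a 1.1-fold higher number from compound 2 to compound 3 (0.03 log units; within the scatter)). The gain is only relative to the other phenyl compounds, as 4-nitrophenyl in place of hexyl stays within the scatter (a 1.6-fold lower number from compound 1 to compound 4 (0.21 log units; within the scatter)), so compound 4 cannot be ranked against the hexyl compound. No measurement here explains why the nitro compound differs from the other two phenyl compounds.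

3-bromophenyl and 4-nitrophenyl differ both in the group and in where it sits on the phenyl, so the compounds shown cannot separate the effect of the nitro group from the effect of its place on the ring. On these data alone, it also remains open whether a nitrile, an amine or a carboxylic acid on that phenyl would shift the number as nitro does, or leave it where bromo did.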